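Swapping propanoyl for ethyl on an aromatic nitrogen

This account rests on a few compounds, and the source may have more. Where it says the series, first, only, none or still open, it means among the compounds named here.

Compound 1 (`Cc1c(C)c2c(c(C)c1N)CC(C)(CSCCC(=O)O)O2`) and compound 2 (`Cc1c(C)c2c(c(C)c1N)CC(C)(CCc1ccc(F)cc1)O2`) share a core with compound 3 and carry no added group on the nitrogen of that core. In a functional assay on the whole organism with Mus musculus as the target (a lower number here means that less compound is needed, a higher number that more compound is needed for the effect), compound 1 gives 43 mg/kg as its result, and compound 2 gives 11.5 mg/kg on the same scale. Compound 3 (`CCC(=O)Nc1c(C)c(C)c2c(c1C)CC(C)(C)O2`) gives > 100 mg/kg in this assay and this figure is a limit of the assay, not a number. Compound 3 therefore has no measured dose, while the other two compounds do.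

Compound 4 (`CCNc1c(C)c(C)c2c(c1C)CC(C)(C)O2`) keeps the core of compound 3 and changes one group: ethyl in place of propanoyl on a nitrogen on an aromatic ring. Among the measured compounds shown here, no two measured compounds differ in one place only, so this swap has no direct precedent here. Compounds 1 and 2 also differ from compound 3 elsewhere in the structure, which makes them only a loose guide. Still, neither carries propanoyl, and compound 1 at 43 mg/kg and compound 2 at 11.5 mg/kg both reach a real number. A move towards a lower dose is therefore expected, with an estimated at least 2.8-fold lower number from compound 3 to compound 4 (0.45 log units; beyond the scatter) as its size. The dose expected for compound 4 is an estimated 35 mg/kg within a range from 12 mg/kg to 100 mg/kg as its likely span.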

Compound 4, dose for 50% inhibition: 38.9 mg/kg
Estimate against measurement, compound 4: 1.1-fold (0.05 log units) below, within the range that was stated.
By their numbers in this assay, from the lowest: compound 2; then compounds 4 and 1 (each within the scatter of the next). At a limit, above all of these: compound 3.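

In this assay, among the compounds shown here, ethyl in place of propanoyl on a nitrogen on an aromatic ring gives an at least 2.5-fold lower number from compound 3 to compound 4 (0.41 log units; beyond the scatter), and this is the first comparison here in which nothing else in the structure changes. The earlier compounds shown here could only hint at this, since compounds 1 and 2 also differ from compound 3 elsewhere, whereas compound 4 keeps the same core and reaches a real dose of 38.9 mg/kg, so the group on this nitrogen alone is enough to separate a measurable dose from none. Compound 3 stands at > 100 mg/kg, which is a limit of the assay and not a number, and the step is a minimum rather than a true size because of that limit: the limit of > 100 mg/kg in this assay, at which 1 of the 4 values shown sits.

For the compounds shown here, the single swap removes the carbonyl and shortens the chain together, so a propyl group on this nitrogen would be needed to tell those two changes apart, while an acetyl group or a bare amine on the same core would show how much the chain matters on its own. From the compounds shown here alone, whether ethyl gives a similar result alongside the side chains of compounds 1 and 2 also remains open.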